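The source may hold more compounds than are shown below. What is called first, only, known or untested is meant among the compounds shown, and "the series" means these compounds.

Compound 1, `O=C(O)[C@H]1NC[C@@H](O)[C@H](O)[C@H]1O`: 6.3%
Compound 2, `O=C(O)[C@H]1NC[C@@H](O)[C@H](O)[C@@H]1O`: 42%
Compound 3, `O=C(O)[C@@H]1NC[C@@H](O)[C@H](O)[C@H]1O`: not yet measured

Among the measured compounds shown here, in an assay on isolated protein for inhibition of cytosolic endo-beta-N-acetylglucosaminidase (Homo sapiens), tested at 1000 uM (a lower number here means less inhibition, a higher number more inhibition at the concentration tested (going by the name of the read-out)), compound 1 gives 6.3% and stands at the lower of the two measured numbers; its only measured neighbour is compound 2, which gives 42%. The two are made of the same atoms joined the same way, and the measured step of a number 35.7 percentage points higher from compound 1 to compound 2 (beyond the scatter) can be laid at the door of nothing other than that (the fact that compounds 1 and 2 differ only in the configuration as drawn).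

Compound 3 is again the same set of atoms and bonds; (the two compounds have the same atoms and bonds and differ only in configuration as drawn: 1 of 4 stereo elements differ; a stereocentre at a saturated ring carbon is drawn S in compound 1 and R in compound 3). The centre that is flipped is, however, a different one from the centre flipped between compound 1 and compound 2, so the measured step tells only that a single inversion in this core can shift this assay by a large amount, not in which direction this one will go. With no closer guide, a modest rise from the low value of compound 1 is expected, a number 8.7 percentage points higher from compound 1 to compound 3 (within the scatter), and the result for compound 3 is estimated at 15%, with a wide range from 0% to 50%.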

Compound 3, a percentage reported as inhibition, at one concentration (the size of the read-out at that concentration, not a potency): 50%
Compound 3: the middle estimate sits 35 percentage points below what was measured; low and high end bracket the measured number.
By their numbers in this assay, from the lowest: compound 1; then compounds 2 and 3 (each within the scatter of the next).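

In this assay, inverting this second ring centre gives a number 43.7 percentage points higher from compound 1 to compound 3 (beyond the scatter), so the drawn arrangement at more than one centre of the shared core can move the read-out by a large amount: the fact that compounds 1 and 3 differ only in the configuration as drawn. The two single inversions away from compound 1 point the same way and land close together, with a number 8 percentage points higher from compound 2 to compound 3 (within the scatter), even though the two products of those inversions differ from each other at two centres: the fact that compounds 2 and 3 differ only in the configuration as drawn. The low number of compound 1 therefore goes with its particular arrangement of centres and not with its atoms, which all three compounds share.

From the compounds shown here alone, what happens when both of these centres are inverted together stays open, as does the effect of inverting either of the other two stereo elements, and a single tested concentration gives no potency for any of the three. All three compounds also carry the same carboxylic acid, so what an amide or a primary alcohol in its place would do to this read-out is an open question.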